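Hydroxy to Fluoro on the Aromatic Ring: What to Expect

This account rests on a few compounds, and the source may have more. Where it says the series, first, only, none or still open, it means among the compounds named here.

Of the compounds shown here, three sharing one core have been tested in a functional assay on NCI-H460 cells (Homo sapiens) for inhibition, read by sulforhodamine B assay, with a stated time of 48 h; a lower number here means a stronger inhibitor of growth, a higher number a weaker inhibitor of growth. Compound 1 `CC1=CC[C@H](C(C)(C)N=C=S)CC1` carries the shortest side group; in this assay compound 1 reaches only the assay limit, > 100000 nM. Compound 2 `CC1=CC[C@H](C(C)(C)NC(=S)NN)CC1` carries a larger side group in its place. In this assay compound 2 likewise gives only a limit, > 100000 nM. Going by the values given here, the single measured step, a step that the two limits leave unreadable from compound 1 to compound 2, therefore cannot be read in size or direction, since both of its ends are limits. Compound 3 `CC1=CC[C@H](C(C)(C)NC(=S)N/N=C/c2ccc(O)cc2)CC1` extends that side group with a 4-hydroxyphenyl ring. In this assay compound 3 again gives only a limit, > 100000 nM. So compound 3 stands exactly where the other two stand, at the limit of > 100000 nM in this assay, at which 3 of the 3 values shown sit, and nothing so far separates any of the three.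

Compound 4 `CC1=CC[C@H](C(C)(C)NC(=S)N/N=C/c2ccc(F)cc2)CC1` differs from compound 3 by fluoro in place of hydroxy on an aromatic carbon, that is, 4-hydroxyphenyl becomes 4-fluorophenyl. Among the compounds with values here, no measured step bears on this change with a readable size; the only step available is the unreadable one, a step that the two limits leave unreadable from compound 1 to compound 2. Within the data shown here, because every value so far sits at the limit of > 100000 nM in this assay, at which 3 of the 3 values shown sit, compound 4 is expected to land near 100000 nM, within 40000 nM to 300000 nM, and most likely to be reported once more as a limit. The expected step of a number no higher from compound 3 to compound 4 (the limit leaves the size open) is accordingly none beyond the scatter.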

Compound 4, concentration for total growth inhibition: > 100000 nM
Compound 4 ended at the assay's limit; the forecaster's own chance of this, stated with the estimate: 80%; the middle value lies on the limit itself.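

In this assay, compound 3 and compound 4 each give only a limit of the assay rather than a number, and the step between them, fluoro in place of hydroxy, cannot be read. The compounds shown leave open how strongly any of the four inhibits growth and whether that swap changes anything, with every value still a limit: the limit of > 100000 nM in this assay, at which 4 of the 4 values shown sit.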